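Furan-3-yl in place of furan-2-yl on the shared core

A few compounds are considered here, and "the series" means these few. Any claim that something is new, unique, unknown or untested is made for them only; others in the source may bear on it.

In a functional assay on HeLa S3 cells (Homo sapiens) for antiproliferative activity, read by XTT assay, with a stated time of 72 h (on this read-out higher numbers stand for weaker inhibition and lower numbers for stronger inhibition), compound 2 (`CNc1ncnc2c1c(-c1ccco1)cn2[C@@H]1O[C@H](CO)[C@@H](O)[C@H]1O`) gives 5000 nM and compound 1 (`CSc1ncnc2c1c(-c1ccoc1)cn2[C@@H]1O[C@H](CO)[C@@H](O)[C@H]1O`) gives 5390 nM on the same read-out, so the two stand level within the usual scatter of repeated measurements. Compound 3 (`CNc1ncnc2c1c(-c1ccoc1)cn2[C@@H]1O[C@H](CO)[C@@H](O)[C@H]1O`) differs from compound 2 in one place: furan-3-yl in place of furan-2-yl on an aromatic carbon. That carbon belongs to a five-membered aromatic ring with 1 nitrogen, part of a fused or bridged system of two rings. Among the compounds with values here, no measured pair isolates this exchange, so the data give no direct size for it. Within the data shown here, compound 1, which carries furan-3-yl, gives 5390 nM in this assay and thus offers the only indirect guide, and it stands level with compound 2 at 5000 nM on these numbers. No shift beyond the scatter is therefore expected. The expected step of a 1.1-fold lower number from compound 2 to compound 3 (0.05 log units; within the scatter) stays within the scatter and has no clear direction. For compound 3 the estimated value is 4500 nM with an expected range of 1300 nM to 15000 nM in all likelihood.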

Compound 3, half-maximal inhibitory concentration: > 20000 nM
Compound 3 was reported as a limit; the forecaster's own chance of this, stated with the estimate: 15%; at least 4.4-fold (0.64 log units) between middle value and limit.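

In this assay, furan-3-yl in place of furan-2-yl on this aromatic carbon gives an at least 4.0-fold higher number from compound 2 to compound 3 (0.60 log units; beyond the scatter), so the read-out tells these two furan groups apart at this position even though they have the same atoms, joined differently. With furan-3-yl kept in place, methylamino in place of methylsulfanyl on an aromatic carbon gives an at least 3.7-fold higher number from compound 1 to compound 3 (0.56 log units; beyond the scatter), so the furan-3-yl group does not by itself set the result, and the other exchange on the shared core also matters in this series. Both steps give only a lower bound on their size, because compound 3 is reported as a limit of the assay and not as a number: the limit of > 20000 nM in this assay, at which 1 of the 3 values shown sits.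

The compounds shown leave open whether the change from furan-2-yl to furan-3-yl would give a step of similar size with methylsulfanyl on the shared core instead of methylamino. They also leave open how a primary amine or a dimethylamino group in place of methylamino, or a thiophene or phenyl ring in place of the furan, would read in this assay.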